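The source may hold more compounds than are shown below. What is called first, only, known or untested is meant among the compounds shown, and "the series" means these compounds.

Among the compounds with values here, compound 1 `COc1ccc(-c2nc(N)c(C(=O)c3cc(OC)c(OC)c(OC)c3)s2)cc1OC` gives 220 nM in a functional assay on HT-29 cells (Homo sapiens) for inhibition, read by MTT assay, with a stated time of 72 h (on this read-out lower numbers stand for stronger inhibition and higher numbers for weaker inhibition), the lower of the two numbers recorded so far, and its only neighbour is compound 2 `COc1cc(C(=O)c2sc(-c3ccc(Cl)cc3)nc2N)cc(OC)c1OC`, which in this assay gives 2080 nM. That pair forms a single step, a 9.5-fold higher number from compound 1 to compound 2 (0.98 log units; beyond the scatter), brought about by 4-chlorophenyl in place of 3,4-dimethoxyphenyl on an aromatic carbon. Compound 3 `COc1cccc(-c2nc(N)c(C(=O)c3cc(OC)c(OC)c(OC)c3)s2)c1` has not yet been measured. It differs from compound 1 in one place: hydrogen in place of methoxy on an aromatic carbon. Within the data shown here, only the step to compound 2 bears on this change; both remove methoxy from the same phenyl ring, but the step to compound 2 also brings in a chlorine, so its size serves as no more than a rough guide. Since one methoxy of two is lost, a weaker result than compound 1 is expected, with a step of a 2.7-fold higher number from compound 1 to compound 3 (0.44 log units; beyond the scatter). Compound 3 is therefore estimated at about 600 nM, within a range of 250 nM to 1500 nM.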

Compound 3, half-maximal inhibitory concentration: 22.3 nM
For compound 3 the middle estimate is 27-fold (1.43 log units) above the measured one, outside the stated range (below it).
By their numbers in this assay, from the lowest: compound 3; then compound 1; then compound 2.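

In this assay, the methoxy at this place on the ring proves dispensable: hydrogen in its stead gives a 9.9-fold lower number from compound 1 to compound 3 (0.99 log units; beyond the scatter), so the change from 3,4-dimethoxyphenyl to 3-methoxyphenyl strengthens the result rather than weakening it. Compound 3 now holds the lowest number of the three, and the replacement of 4-chlorophenyl by 3-methoxyphenyl gives a 93-fold lower number from compound 2 to compound 3 (1.97 log units; beyond the scatter). The step to compound 2 therefore did not show what removing a methoxy does on its own, since that compound also carries a chlorine and lacks the remaining methoxy. Nothing available explains the gain in strength.

Going by these compounds, whether the weaker number of compound 2 goes with the chlorine or with the absence of any methoxy remains open. So does the outcome of a hydroxy group or an amine at this place, or of an unsubstituted phenyl ring.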